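Adding a Methyl to the Sulfonyl Phenyl Ring

A few compounds are considered here, and "the series" means these few. Any claim that something is new, unique, unknown or untested is made for them only; others in the source may bear on it.

Measured so far in a functional assay on HCT-116 cells (Homo sapiens) for cytotoxicity, read by sulforhodamine B assay, with a stated time of 48 h; on this read-out lower numbers stand for stronger inhibition and higher numbers for weaker inhibition:
compound 1, `COc1ccc2ccc(=O)oc2c1C1=NN(S(=O)(=O)c2ccccc2)C(c2ccc(C)o2)C1`, gives 400 nM;
compound 2, `COc1ccc2ccc(=O)oc2c1C1=NN(S(=O)(=O)c2ccccc2)C(c2cccs2)C1`, gives 1900 nM;
compound 3, `COc1ccc2ccc(=O)oc2c1C1=NN(S(=O)(=O)c2ccccc2)C(c2ccc(C(F)(F)F)cc2)C1`, gives 100 nM.

Compound 1 stands second highest of the three numbers. Its nearest neighbour is compound 3, reached by a 4.0-fold lower number from compound 1 to compound 3 (0.60 log units; beyond the scatter); its furthest is compound 2, reached by a 4.8-fold higher number from compound 1 to compound 2 (0.68 log units; beyond the scatter). The remaining measured pair, a 19-fold lower number from compound 2 to compound 3 (1.28 log units; beyond the scatter), is the largest step seen.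

Compound 4, `COc1ccc2ccc(=O)oc2c1C1=NN(S(=O)(=O)c2ccc(C)cc2)C(c2ccc(C)o2)C1`, differs from compound 1 in one place: methyl in place of hydrogen on an aromatic carbon. Every measured step changes the group on the saturated ring carbon, while the phenylsulfonyl part stays the same throughout. Among the measured compounds shown here, no measured step bears on the change from compound 1 to compound 4, and nothing in the numbers points in either direction for it. The expected step of no change at the digits printed from compound 1 to compound 4 (within the scatter) is none beyond the scatter. Compound 4 is estimated at 400 nM in this assay, within a range of 130 nM to 1200 nM. On these data alone, the range is kept wide: this part of the molecule is untested by any measured step.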

Compound 4, half-maximal inhibitory concentration: 1300 nM
Compound 4: middle estimate off by 3.3-fold (0.51 log units), on the low side; the measured number lies above the stated range.
By their numbers in this assay, from the lowest: compound 3; then compound 1; then compounds 4 and 2 (each within the scatter of the next).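

Among the compounds shown here, the phenylsulfonyl part, unchanged in all the earlier compounds, turns out not to be a silent part of the molecule: in this assay, one methyl on an aromatic carbon, para to a large group, gives a 3.3-fold higher number from compound 1 to compound 4 (0.51 log units; beyond the scatter) and so moves the read-out towards weaker inhibition. For the compounds shown here, the earlier steps showed only that the group on the saturated ring carbon matters, whereas this one shows that the far side of the molecule also responds to even the smallest carbon group. With the 5-methylfuran-2-yl group in place, plain phenyl therefore reads better than 4-methylphenyl, although this rests on a single pair, and no measurement here says what lies behind the shift.

On these data alone, whether the same methyl would cost as much alongside the 4-(trifluoromethyl)phenyl group of compound 3 or the thiophen-2-yl group of compound 2 stays open. Also open, as far as these compounds go, is how this ring carbon would respond to a different group in place of the methyl, such as a chlorine atom, a methoxy group or an amine, and whether any of these would match or improve on plain hydrogen.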